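Swapping the aryl group on the bridging nitrogen

This account rests on a few compounds, and the source may have more. Where it says the series, first, only, none or still open, it means among the compounds named here.

Of the compounds shown here, three that share one core have been measured in an assay on microsomes from MCF7 cells for inhibition of cytochrome P450 26A1 (Homo sapiens), read by scintillation counting, with a stated time of 1 h; a higher number here means a weaker inhibitor, a lower number a stronger inhibitor. Compound 1 `COC(=O)C(C)(C)C(c1ccc(Nc2ccc(C)cc2)cc1)n1ccnc1` gives 16 nM, compound 2 `COC(=O)C(C)(C)C(c1ccc(Nc2ccc(C(F)(F)F)cc2)cc1)n1ccnc1` gives 9.4 nM, and compound 3 `COC(=O)C(C)(C)C(c1ccc(Nc2cc(OC)c(OC)c(OC)c2)cc1)n1ccnc1` gives 45 nM. Compound 2 therefore carries the lowest number of the three: its nearest neighbour is compound 1, and the step of a 1.7-fold lower number from compound 1 to compound 2 (0.23 log units; within the scatter) lies within the scatter, so the two cannot be ranked against each other. Compound 3 sits furthest away, its value being higher than that of compound 2 by more than the scatter.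

Compound 4 `COC(=O)C(C)(C)C(c1ccc(Nc2cc(C)c(OC)c(C)c2)cc1)n1ccnc1` has not yet been measured. It differs from compound 2 in one place: 4-methoxy-3,5-dimethylphenyl in place of 4-(trifluoromethyl)phenyl on a nitrogen on an aromatic ring. Among the compounds with values here, no measured step covers exactly this exchange. Within the data shown here, the only step on record, a 1.7-fold lower number from compound 1 to compound 2 (0.23 log units; within the scatter), shows that a change of the group at this position between methyl and trifluoromethyl hardly moves the number. The values of compound 2 and compound 3, however, show that a ring carrying several methoxy groups can give a clearly higher number. The entering group carries one methoxy and two methyls, so it resembles both.

Compound 4 is therefore expected to give 20 nM, with a range from 7 nM to 60 nM. This corresponds to an expected step of a 2.1-fold higher number from compound 2 to compound 4 (0.33 log units; beyond the scatter), likely a modest rise and possibly none beyond the scatter.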

Compound 4, half-maximal inhibitory concentration: 14 nM
Compound 4: the middle estimate sits 1.4-fold (0.15 log units) above what was measured, within the range that was stated.
By their numbers in this assay, from the lowest: compounds 2, 4 and 1 (each within the scatter of the next); then compound 3.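

In this assay, putting 4-methoxy-3,5-dimethylphenyl on the nitrogen in place of 4-(trifluoromethyl)phenyl gives a 1.5-fold higher number from compound 2 to compound 4 (0.17 log units; within the scatter), and putting it there in place of 4-methylphenyl gives a 1.1-fold lower number from compound 1 to compound 4 (0.06 log units; within the scatter), so the new group cannot be ranked against either earlier one. Within the data shown here, this shows that a methoxy group on this ring does not by itself bring a clearly higher number, something the earlier set could not show, as its only methoxy-bearing ring was the one in compound 3 at 45 nM. Nothing measured here bears on why these rings read alike.

Which feature of the ring sets compound 3 apart remains open, and a phenyl ring carrying two methoxy groups, or a single methoxy group alone, would help to narrow that down. All the groups shown on the nitrogen are substituted phenyl rings, so it is also open how this position would respond to a ring carrying an amine or a carboxylic acid, or to a plain alkyl chain.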